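Trimethoxyphenyl in place of cyanophenyl: an open step

The source may hold more compounds than are shown below. What is called first, only, known or untested is meant among the compounds shown, and "the series" means these compounds.

Measured in a functional assay on QGY-7703 cells (Homo sapiens) for cytotoxicity, read by MTT assay, with a stated time of 24 h; on this read-out lower numbers stand for stronger inhibition and higher numbers for weaker inhibition:
Compound 1 `N#Cc1ccc(/C=C2\CN(S(=O)(=O)c3ccc(F)cc3)C/C(=C\c3ccc(C#N)cc3)C2=O)cc1`: 11300 nM
Compound 2 `CC(=O)Nc1ccc(S(=O)(=O)N2C/C(=C\c3ccc(C#N)cc3)C(=O)/C(=C/c3ccc(C#N)cc3)C2)cc1`: 3320 nM
Compound 3 `CC(=O)Nc1ccc(S(=O)(=O)N2C/C(=C\c3cccc([N+](=O)[O-])c3)C(=O)/C(=C/c3ccccc3F)C2)cc1`: 7850 nM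

Compound 2, at 3320 nM, holds the lowest of the three numbers in this assay. Compound 3 comes nearest at 7850 nM, and compound 1 lies furthest at 11300 nM; both gaps lie beyond the scatter.

The next compound, compound 4 `COc1cc(/C=C2\CN(S(=O)(=O)c3ccc(NC(C)=O)cc3)C/C(=C\c3ccc(C#N)cc3)C2=O)cc(OC)c1OC`, has not yet been measured. It carries 3,4,5-trimethoxyphenyl in place of 4-cyanophenyl on a double-bonded chain carbon bound to a double-bonded ring carbon.

For the measured compounds named here, only one measured step links two compounds that differ in one place: a 3.4-fold lower number from compound 1 to compound 2 (0.53 log units; beyond the scatter). This modest step exchanged fluoro for acetamido on an aromatic carbon, not the group that changes here, so it bears on the new change only indirectly. Going by the values given here, no measured compound carries 3,4,5-trimethoxyphenyl, and compound 3 differs from compound 2 in more than one place. The data therefore give no direction, and no step beyond the scatter is expected in this assay. The estimate leans slightly upward, since compound 2 at 3320 nM already holds the lowest number. The expected change is a 1.4-fold higher number from compound 2 to compound 4 (0.13 log units; within the scatter). For compound 4 the estimated value is 4500 nM, with an expected range from 1500 nM to 13000 nM.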

Compound 4, half-maximal inhibitory concentration: 1890 nM
Beside the measured number, compound 4's estimate is 2.4-fold (0.38 log units) above it; the measured number falls inside the stated range.
By their numbers in this assay, from the lowest: compounds 4 and 2 (each within the scatter of the next); then compounds 3 and 1 (each within the scatter of the next).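

In this assay, for the compounds shown here, putting 3,4,5-trimethoxyphenyl in place of 4-cyanophenyl on a double-bonded chain carbon bound to a double-bonded ring carbon gives a 1.8-fold lower number from compound 2 to compound 4 (0.24 log units; within the scatter), a step within the scatter and the first single-place comparison at this position. It shows that a group of 12 heavy atoms carrying three oxygens can replace one of 8 heavy atoms carrying a nitrile here without a change beyond the scatter, at least while the acetamido group and the second 4-cyanophenyl group stay in place. No measurement is available that would explain this outcome.

The compounds shown leave open whether a smaller group at this position, such as a single methoxy or hydroxyl on the phenyl ring, or a basic group such as a dimethylamino substituent, would also stay within the scatter. They also leave open whether 3,4,5-trimethoxyphenyl would give a similar result with fluoro in place of acetamido, or if it replaced the second 4-cyanophenyl group as well.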